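Methoxy for methyl on the shared core

This account rests on a few compounds, and the source may have more. Where it says the series, first, only, none or still open, it means among the compounds named here.

Measured compounds:
compound 1 `Cc1ccc(NC(=O)c2coc3ccc(C)cc3c2=O)cc1` — 152 nM
compound 2 `COc1ccc2oc(=O)c(C(=O)Nc3ccccc3)cc2c1` — 5.95 nM

In an assay on cells for inhibition of Amine oxidase [flavin-containing] B (Homo sapiens), read by fluorescence and Amplex Red, using microsomes, with a stated time of 15 min (a lower number here means a stronger inhibitor, a higher number a weaker inhibitor), compound 1 gives 152 nM, the highest of the two numbers in hand. The nearest measured compound, compound 2, gives 5.95 nM in this assay; the gap between the two lies beyond the usual scatter, but compound 2 differs from compound 1 in more than one place, so no single step can be read off from that pair.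

Compound 3 `COc1ccc2occ(C(=O)Nc3ccc(C)cc3)c(=O)c2c1` keeps the core and the amide partner of compound 1 and changes one group: methoxy in place of methyl on an aromatic carbon. For the measured compounds named here, no measured pair isolates this change. Going by the values given here, compound 2, the only compound carrying a methoxy on its core, sits far lower than compound 1 in this assay, which supports expecting a move toward lower numbers, though its other differences leave the size uncertain. The expected step of a 2.5-fold lower number from compound 1 to compound 3 (0.40 log units; beyond the scatter) is a moderate decrease, somewhat beyond the scatter. Compound 3 is estimated at 60 nM in this assay, with a range of 15 nM to 250 nM.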

Compound 3, half-maximal inhibitory concentration: 211 nM
The estimate for compound 3 lay 3.5-fold (0.55 log units) below the measured number, within the range that was stated.
By their numbers in this assay, from the lowest: compound 2; then compounds 1 and 3 (each within the scatter of the next).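

Methoxy in place of methyl on an aromatic carbon of the shared core, read in this assay, gives a 1.4-fold higher number from compound 1 to compound 3 (0.14 log units; within the scatter), so the two groups cannot be told apart at this position. For the compounds shown here, with the core and the amide partner held fixed, this place on the ring accepts the larger group with no change beyond the scatter, and this pair is the only single-place reading of the change so far. Nothing in hand bears on why the two groups read alike.

From the compounds shown here alone, whether an amine, a chlorine or an ethoxy group at this same position would shift the number remains open. Also open, going by these compounds, is which of its differences gives compound 2 its 5.95 nM, since compound 2 differs from compound 1 and compound 3 in more than one place.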